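A few compounds are considered here, and "the series" means these few. Any claim that something is new, unique, unknown or untested is made for them only; others in the source may bear on it.

Compound 1 `O=C1C[C@H](O)C[C@@H](/C=C/c2c(Cl)cc(Cl)cc2-c2cc(Cl)cc(Cl)c2)O1` — 37 nM
Compound 2 `Cc1cc(-c2cc(Cl)cc(Cl)c2/C=C/[C@@H]2C[C@@H](O)CC(=O)O2)ccc1F` — 29 nM
Compound 3 `Cc1cc(C)cc(-c2cc(Cl)cc(Cl)c2/C=C/[C@@H]2C[C@@H](O)CC(=O)O2)c1` — 13 nM

In an assay for inhibition of 3-hydroxy-3-methylglutaryl-coenzyme A reductase (Rattus norvegicus) (a lower number here means a stronger inhibitor, a higher number a weaker inhibitor), compound 3 stands lowest of the three numbers. The two steps that reach it are a 2.2-fold lower number from compound 2 to compound 3 (0.35 log units; beyond the scatter) and a 2.8-fold lower number from compound 1 to compound 3 (0.45 log units; beyond the scatter), both beyond the scatter, so compound 3 is the strongest inhibitor of the set. Compound 4 `CCc1cccc(-c2cc(Cl)cc(Cl)c2/C=C/[C@@H]2C[C@@H](O)CC(=O)O2)c1` differs from compound 3 in one place: 3-ethylphenyl in place of 3,5-dimethylphenyl on an aromatic carbon. The two measured steps that reach compound 3 both change the group on this aromatic carbon, and both were modest; the step from compound 1 to compound 2, which also changes that group, stayed within the scatter. Compound 4 keeps the same atoms as compound 3, only joined differently, and the varied groups so far have moved this assay by small amounts. A small shift, if any, is therefore expected. Compound 4 is expected to give 20 nM in this assay, with a range from 8 nM to 50 nM. This estimate means a step of a 1.5-fold higher number from compound 3 to compound 4 (0.19 log units; within the scatter), expected to fall within the scatter.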

Compound 4, half-maximal inhibitory concentration: 44 nM
Compound 4: the middle estimate sits 2.2-fold (0.34 log units) below what was measured, and the stated range covers the measured number.
By their numbers in this assay, from the lowest: compound 3; then compounds 2, 1 and 4 (each within the scatter of the next).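

In this assay, the 3-ethylphenyl and 3,5-dimethylphenyl groups have the same count of heavy atoms, all carbon, yet joining those atoms differently gives a 3.4-fold higher number from compound 3 to compound 4 (0.53 log units; beyond the scatter), so at this position the arrangement of the carbons matters and not only their number. Among the compounds shown here, the other two new steps, a 1.5-fold higher number from compound 2 to compound 4 (0.18 log units; within the scatter) and a 1.2-fold higher number from compound 1 to compound 4 (0.08 log units; within the scatter), stay within the scatter, which leaves compound 3 as the one compound set apart from the rest and the strongest inhibitor of the four. Nothing measured here accounts for this difference.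

The compounds shown leave open whether the loss follows from the lengthened chain or from the missing second ring substituent, which 3-methylphenyl would help separate. Going by these compounds, how a longer chain such as propyl, or an amine or a methoxy group, would fare on this ring also remains open.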